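Nitro to amino on the anilino ring of compound 2

This account rests on a few compounds, and the source may have more. Where it says the series, first, only, none or still open, it means among the compounds named here.

In a functional assay on K562 cells (Homo sapiens) for antiproliferative activity, read by CellTiter-Glo and CCK-8 assay, with a stated time of 72 h (on this read-out higher numbers stand for weaker inhibition of growth and lower numbers for stronger inhibition of growth), compound 2 `CNc1nc(Nc2ccc(C)c([N+](=O)[O-])c2)ncc1C(=O)Nc1cc(NC(=O)c2cc(OC)cc(OC)c2)ccc1C` gives 1070 nM, and compound 1 `CNc1nc(Nc2ccc(C)c([N+](=O)[O-])c2)ncc1C(=O)Nc1cc(NC(=O)c2ccc(OC)cc2)ccc1C` gives 1530 nM; the step of a 1.4-fold lower number from compound 1 to compound 2 (0.16 log units; within the scatter) leaves the two within the scatter of each other. Compound 3 `CNc1nc(Nc2ccc(C)c(N)c2)ncc1C(=O)Nc1cc(NC(=O)c2cc(OC)cc(OC)c2)ccc1C` differs from compound 2 by amino in place of nitro on an aromatic carbon. Among the measured compounds shown here, the only measured step concerns the methoxy pattern on the carbonyl-bound phenyl and does not bear on this change, so the series gives no guide to its size or direction. The step expected is a 1.1-fold higher number from compound 2 to compound 3 (0.05 log units; within the scatter), with no change beyond the scatter assumed. The estimate for compound 3 is 1200 nM, from 300 nM to 5000 nM.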

Compound 3, concentration for 50% growth inhibition: 230 nM
Beside the measured number, compound 3's estimate is 5.2-fold (0.72 log units) above it; the whole stated range lies above it.
By their numbers in this assay, from the lowest: compound 3; then compounds 2 and 1 (each within the scatter of the next).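

In this assay, the step of a 4.7-fold lower number from compound 2 to compound 3 (0.67 log units; beyond the scatter) is beyond the scatter, so the group ortho to a methyl group on this ring affects the read-out, whereas the methoxy change on the other phenyl stayed within the scatter. Nothing at hand explains the difference.

Still open, as far as these compounds go, is whether the change is specific to amino, which a methylamino, acetamido or hydroxyl group at this position would test. Also open, from the compounds shown here alone, is whether amino gives a similar step with the 4-methoxyphenyl amide of compound 1.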